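The source may report more compounds than this note shows. Statements on the series, on what has been measured and on what is new or still open speak of the compounds shown alone.

The measured compounds:
compound 1 `Cn1c(=O)c(S(=O)(=O)c2ccc([N+](=O)[O-])cc2F)cc2cnc(Nc3ccc4[nH]ccc4c3)nc21`, 200 nM;
compound 2 `Cn1c(=O)c(S(=O)(=O)c2ccc(F)cc2)cc2cnc(Nc3ccc4[nH]ncc4c3)nc21`, 10000 nM;
compound 3 `Cn1ccc2cc(Nc3ncc4cc(S(=O)(=O)c5ccc(Cl)cc5Cl)c(=O)n(C)c4n3)ccc21`, 750 nM.

These values come from a functional assay on K562 cells (Homo sapiens) for inhibition, read by trypan blue exclusion, with a stated time of 72 h; on this read-out higher numbers stand for weaker inhibition and lower numbers for stronger inhibition. Compound 1 has the lowest number of the three; compound 3 stands nearest to it, and compound 2 furthest, both gaps beyond the scatter. The unmeasured compound 4 `Cn1c(=O)c(S(=O)(=O)c2ccc(N)cc2F)cc2cnc(Nc3ccc4[nH]ccc4c3)nc21` differs from compound 1 in one place: amino in place of nitro on an aromatic carbon. For the measured compounds named here, no step between measured compounds that differ in only one place is known, so the size of this change has no direct precedent here. With amino in place of nitro, a modest move toward a higher number is expected in this assay, though it could also remain within the scatter. For compound 4 the estimated value is 600 nM, with a range from 150 nM to 3000 nM. The step this expectation implies is a 3.0-fold higher number from compound 1 to compound 4 (0.48 log units; beyond the scatter).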

Compound 4, half-maximal inhibitory concentration: 1500 nM
The estimate for compound 4 lay 2.5-fold (0.40 log units) below the measured number; the range from low to high includes it.
By their numbers in this assay, from the lowest: compound 1; then compounds 3 and 4 (each within the scatter of the next); then compound 2.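

In this assay, for the compounds shown here, amino in place of nitro on the 2-fluoro-4-nitrophenyl group gives the first single-place comparison here: a 7.5-fold higher number from compound 1 to compound 4 (0.88 log units; beyond the scatter). This shows that the aromatic carbon para to a large group is sensitive to the change, with the nitro compound reading as the stronger inhibitor. Nothing available accounts for this step.

As far as these compounds go, whether other groups on this carbon, such as a nitrile, a methoxy group or a carboxylic acid, would read closer to nitro or to amino remains open. So does whether the same change would give a similar step without the fluoro group.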